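Cycloheptyl to 4-Methylphenyl at the Benzylic Position

The source may hold more compounds than are shown below. What is called first, only, known or untested is meant among the compounds shown, and "the series" means these compounds.

The series shares one core, seen in compound 1 `O=C(O)c1ccccc1-c1ccc(CCc2ncc(CC3CCCCCC3)[nH]2)cc1`, and differs only in the group carried on a saturated chain carbon bound to an aromatic carbon. In an in vitro functional assay on cells for agonist activity at Bombesin receptor subtype-3 (Mus musculus), read by luminescence and calcium flux (a higher number here means that more compound is needed for the effect, a lower number that less compound is needed), compound 1 gives 5.7 nM, the lowest number of the three measured. Compound 2 `Cc1cccc(Cc2cnc(CCc3ccc(-c4ccccc4C(=O)O)cc3)[nH]2)c1`, with 3-methylphenyl, gives 75 nM, and compound 3 `N#Cc1cccc(Cc2cnc(CCc3ccc(-c4ccccc4C(=O)O)cc3)[nH]2)c1`, with 3-cyanophenyl, gives 20 nM. The step of a 13-fold higher number from compound 1 to compound 2 (1.12 log units; beyond the scatter) and the step of a 3.5-fold higher number from compound 1 to compound 3 (0.55 log units; beyond the scatter) both run upward, and within the aryl pair the step of a 3.8-fold lower number from compound 2 to compound 3 (0.57 log units; beyond the scatter) shows that the substituent on the ring also matters.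

Compound 4 `Cc1ccc(Cc2cnc(CCc3ccc(-c4ccccc4C(=O)O)cc3)[nH]2)cc1` is the next member. Against compound 1 its change is 4-methylphenyl in place of cycloheptyl on a saturated chain carbon bound to an aromatic carbon. The two measured steps that bear on it both replaced cycloheptyl by a substituted phenyl and both raised the number, one large and one modest, so an upward step in this assay is expected here as well; since compound 2 carries a methylphenyl and gave 75 nM, the expected step for compound 4 is a 9.6-fold higher number from compound 1 to compound 4 (0.98 log units; beyond the scatter). Compound 4 is therefore estimated at 55 nM, in the range 18 nM to 170 nM.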

Compound 4, half-maximal effective concentration: 162 nM
Beside the measured number, compound 4's estimate is 2.9-fold (0.47 log units) below it, and the stated range covers the measured number.
By their numbers in this assay, from the lowest: compound 1; then compound 3; then compound 2; then compound 4.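

In this assay, replacing cycloheptyl by 4-methylphenyl, a group with the same heavy-atom count, gives a 28-fold higher number from compound 1 to compound 4 (1.45 log units; beyond the scatter), the largest rise yet seen on leaving the saturated ring, and this leaves compound 4 with the highest number of the four. Relocating the methyl within the aryl group is itself enough to shift the result, as 4-methylphenyl in place of 3-methylphenyl gives a 2.2-fold higher number from compound 2 to compound 4 (0.33 log units; beyond the scatter), so the substitution pattern on the phenyl matters as well as the substituent. Against the 3-cyanophenyl group the gap widens to an 8.1-fold higher number from compound 3 to compound 4 (0.91 log units; beyond the scatter), and no measurement at hand accounts for any of these differences.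

The compounds shown leave open whether 4-cyanophenyl would follow the methyl pair and give a higher number than 3-cyanophenyl, and how unsubstituted phenyl would compare with the methylphenyl groups. They also leave open whether a smaller saturated ring such as cyclohexyl, or a ring carrying an amine such as piperidinyl, would keep the low number of the cycloheptyl group.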